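A Fluorine in Place of a Hydroxy Group

The compounds below may be only part of what the source reports. "The series", "measured", "known", "first", "only" and "open" are said of these compounds alone.

Of the compounds shown here, three sharing one core have been measured in an assay for inhibition of Indoleamine 2,3-dioxygenase 1 (Homo sapiens), with a stated time of 1 h, tested at 10 uM; on this read-out lower numbers stand for less inhibition and higher numbers for more inhibition at the one concentration tested (going by the name of the read-out). Compound 3 `Oc1ccc(CNc2cc(Br)cc3[nH]ncc23)cc1O` gives 50%, the highest of the three numbers. Its nearest neighbour is compound 1 `Oc1cccc(CNc2cc(Br)cc3[nH]ncc23)c1`, which gives 45%; the step of a number 5 percentage points higher from compound 1 to compound 3 (within the scatter) comes from hydroxy in place of hydrogen on an aromatic carbon. Compound 2 `CC(Nc1cc(Br)cc2[nH]ncc12)c1ccccc1` gives 14%, far below compound 3. Compound 4 `Oc1ccc(CNc2cc(Br)cc3[nH]ncc23)cc1F` has not been measured; it differs from compound 3 by fluoro in place of hydroxy on an aromatic carbon. Among the compounds with values here, the only step that bears on this change is the one from compound 1 to compound 3, which stayed within the scatter, so losing the hydroxy should matter little; what fluorine does there has not been tested. The expected step is a number 7 percentage points lower from compound 3 to compound 4 (within the scatter). Compound 4 is estimated in this assay at 43%, between 25% and 60%.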

Compound 4, a percentage reported as inhibition, at one concentration (the size of the read-out at that concentration, not a potency): 52%
For compound 4 the middle estimate is 9 percentage points below the measured one, and the stated range covers the measured number.
By their numbers in this assay, from the lowest: compound 2; then compounds 1, 3 and 4 (each within the scatter of the next).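

Exchanging the hydroxy group that sits meta to a large group for fluoro gives a number 2 percentage points higher from compound 3 to compound 4 (within the scatter). Within the data shown here, the earlier step concerned the other hydroxy group, so this is the first reading at this place, and it shows that a fluoro group, with 0 hydrogen-bond donors and 0 hydrogen-bond acceptors, can stand there without a change beyond the scatter. No outside measurement accounts for this result. Open, on these data alone, is how a larger or charged group would fare at this place, such as methoxy, an amine or a carboxylic acid. Also open, as far as these compounds go, is whether a plain hydrogen there would give a similar number.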